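Replacing the pyridin-2-yl of compound 2 with phenyl

The source may hold more compounds than are shown below. What is called first, only, known or untested is meant among the compounds shown, and "the series" means these compounds.

Compound 1 `O=C(NCCCCN1CCCCC1)Nc1ccc(-c2ccc(F)cc2)cc1` gives 5800 nM in a functional assay on HEK293 cells for agonist activity at 5-hydroxytryptamine receptor 3A (Homo sapiens), read by FLIPR (a higher number here means a weaker inhibitor, a lower number a stronger inhibitor), and compound 3 `O=C(NCCCCN1CCCCC1)Nc1ccc(-c2ccccc2F)cc1` gives 5700 nM; the step of a 1.0-fold lower number from compound 1 to compound 3 (0.01 log units; within the scatter) is within the scatter. Compound 2 `O=C(NCCCCN1CCCCC1)Nc1ccc(-c2ccccn2)nc1` reaches only the limit > 30000 nM in this assay, so it stands at the edge of the numbers shown, as noted in the limit of > 30000 nM in this assay, at which 1 of the 3 values shown sits. Compound 4 `O=C(NCCCCN1CCCCC1)Nc1ccc(-c2ccccc2)nc1` carries the change (phenyl in place of pyridin-2-yl on an aromatic carbon). Among the measured compounds shown here, the only measured step, from compound 1 to compound 3, moves a fluorine on the distal ring and does not cover a pyridin-2-yl to phenyl exchange, so no measured step bears directly on it. From a limit, the expected step of an at least 2.0-fold lower number from compound 2 to compound 4 (0.30 log units; that floor lies within the scatter) can only run toward a lower number, and its size is uncertain. Compound 4 is expected at 15000 nM, with a range from 5000 nM to 40000 nM.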

Compound 4, half-maximal inhibitory concentration: > 30000 nM
Compound 4: a limit, no number; the forecaster's own chance of this, stated with the estimate: 35%; middle value at least 2.0-fold (0.30 log units) away from the limit.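

Compound 2 and compound 4 both stand as limits, not numbers, in this assay, so the step between them cannot be read: the limit of > 30000 nM in this assay, at which 2 of the 4 values shown sit.

As far as these compounds go, whether phenyl and pyridin-2-yl differ at all in this assay stays open.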